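The source may hold more compounds than are shown below. What is called first, only, known or untested is meant among the compounds shown, and "the series" means these compounds.

Measured compounds:
- compound 1 `Cc1nc(C(C)(C)C)nc2nc(N)c(C#N)c(N)c12`: 37000 nM
- compound 2 `CC(C)(C)c1nc(-c2ccn[nH]2)c2c(N)c(C#N)c(N)nc2n1`: 13500 nM

In a physicochemical assay for solubility, in phosphate buffer, with a stated time of 18 h (on this read-out higher numbers stand for higher solubility and lower numbers for lower solubility), compound 1 gives 37000 nM, the higher of the two numbers, while compound 2 gives 13500 nM. Among the compounds with values here, the one step between them, a 2.7-fold lower number from compound 1 to compound 2 (0.44 log units; beyond the scatter), is a modest fall in this assay that lies beyond the scatter.

Compound 3 `CC(C)(C)c1nc(-c2ncco2)c2c(N)c(C#N)c(N)nc2n1` has not yet been measured in this assay. It differs from compound 1 as follows: 1,3-oxazol-2-yl in place of methyl on an aromatic carbon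

Within the data shown here, the only step that bears on this change is the one from compound 1 to compound 2, where another five-membered aromatic ring took the place of the same methyl at the same position and gave a 2.7-fold lower number from compound 1 to compound 2 (0.44 log units; beyond the scatter). By analogy, a step of similar size and direction is expected here, so the number for compound 3 is estimated to come out lower than that of compound 1 by a 2.5-fold lower number from compound 1 to compound 3 (0.39 log units; beyond the scatter). Compound 3 is therefore expected to give about 15000 nM in this assay, within a range of 5000 nM to 40000 nM.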

Compound 3, solubility: 50000 nM
Estimate against measurement, compound 3: 3.3-fold (0.52 log units) below; measured number above the stated range.
By their numbers in this assay, from the lowest: compound 2; then compounds 1 and 3 (each within the scatter of the next).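

In this assay the step (a 1.4-fold higher number from compound 1 to compound 3 (0.13 log units; within the scatter)) shows that 1,3-oxazol-2-yl can take the place of methyl on this aromatic carbon without a change beyond the scatter, so a five-membered aromatic ring at this position does not always bring the fall seen with compound 2. The two rings also part from each other, with the step (a 3.7-fold higher number from compound 2 to compound 3 (0.57 log units; beyond the scatter)) lying beyond the scatter, so at this position the read-out follows the identity of the ring and not merely the presence of one. Nothing shown explains this difference between the two rings.

From the compounds shown here alone, it remains open how an amine, a carboxylic acid or a pyridin-2-yl ring on this aromatic carbon would read in this assay. Going by these compounds, it also remains open whether the gap between 1,3-oxazol-2-yl and 1H-pyrazol-5-yl would hold on any other core.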